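Swapping an Ester for a Nitrile on the Ring

The source may report more compounds than this note shows. Statements on the series, on what has been measured and on what is new or still open speak of the compounds shown alone.

In an ADME assay on a cell-free system (plasma, Homo sapiens) for metabolic stability (on this read-out higher numbers stand for a longer-lived compound and lower numbers for a shorter-lived compound), three compounds built on a shared core have been measured so far. Compound 1 `CC(=O)OCOC(=O)N(C)/N=N/c1ccc(Br)cc1` gives 0.283 h. Compound 2 `CCOC(=O)c1ccc(/N=N/N(C)C(=O)OCOC(=O)c2ccccc2OC(C)=O)cc1` gives 0.0167 h. Compound 3 `CCOC(=O)c1ccc(/N=N/N(C)C(=O)OCOC(C)=O)cc1` gives 0.2 h, the second highest of the three numbers; its gap to compound 1 is within the scatter, so these two cannot be told apart, while compound 2 sits far lower, as the step of a 12-fold higher number from compound 2 to compound 3 (1.08 log units; beyond the scatter) shows.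

Compound 4 `CC(=O)OCOC(=O)N(C)/N=N/c1ccc(C#N)cc1` has not yet been measured. It differs from compound 3 in one place: cyano in place of ethoxycarbonyl on an aromatic carbon. The comparison that bears most directly on this is the step of a 1.4-fold lower number from compound 1 to compound 3 (0.15 log units; within the scatter), which also exchanged one group, bromo, for ethoxycarbonyl on an aromatic carbon and left the half-life essentially where it was. The large step of a 12-fold higher number from compound 2 to compound 3 (1.08 log units; beyond the scatter) concerns a different group, the one on a carbonyl carbon, and so says little about a change on the aromatic ring. Among the measured compounds shown here, with the one relevant step lying within the scatter, the expectation is that compound 4 will show a step of a 1.1-fold higher number from compound 3 to compound 4 (0.04 log units; within the scatter), that is, no movement beyond the usual scatter. The estimate for compound 4 is therefore 0.22 h, with a range from 0.1 h to 0.5 h.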

Compound 4, half-life: 0.117 h
Beside the measured number, compound 4's estimate is 1.9-fold (0.27 log units) above it; the range from low to high includes it.
By their numbers in this assay, from the lowest: compound 2; then compounds 4, 3 and 1 (each within the scatter of the next, the first and the last beyond it).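

Putting cyano in place of ethoxycarbonyl on this aromatic carbon, para to a large group, gives a 1.7-fold lower number from compound 3 to compound 4 (0.23 log units; within the scatter), so this swap stays inside the normal spread of repeat measurements, as the earlier swap from bromo to ethoxycarbonyl did. The new information comes from the direct comparison of the other two groups: cyano in place of bromo gives a 2.4-fold lower number from compound 1 to compound 4 (0.38 log units; beyond the scatter), the only change at this position shown here that passes beyond the scatter, although the step is modest, so the group at this position can make a measurable difference to the half-life even though neither of the two steps through ethoxycarbonyl can be told from scatter on its own. The data shown offer nothing that could account for this difference.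

With only bromo, ethoxycarbonyl and cyano shown at this position, it remains open whether an amine or a carboxylic acid there would keep the half-life within the same narrow band. Also open, going by these compounds, is whether these ring swaps would have the same effect with 2-acetoxyphenyl on the carbonyl carbon, as in compound 2, since each of the three ring groups compared here has methyl in that place.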